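Chloro in place of hydrogen on the aryl urea

The compounds below may be only part of what the source reports. "The series", "measured", "known", "first", "only" and "open" are said of these compounds alone.

Measured compounds:
compound 1 `CN(C)CCCNc1nc(-c2ccc(NC(=O)Nc3ccc(Cl)cc3Cl)cc2)nc2c(Cl)c(Cl)sc12`: 1320 nM
compound 2 `CN(C)CCNc1nc(-c2ccc(NC(=O)Nc3ccc(Cl)cc3)cc2)nc2c(Cl)c(Cl)sc12`: 460 nM

In a functional assay on HT-29 cells (Homo sapiens) for cytotoxicity, read by MTT assay, with a stated time of 72 h (a lower number here means a stronger inhibitor, a higher number a weaker inhibitor), compound 2 gives the lower of the two numbers; compound 1 gives a number that is beyond the scatter above it. Compound 1 carries a 2,4-dichlorophenyl group and a longer dimethylamino chain, so its gap to compound 2 cannot be assigned to one change. Compound 3 `CN(C)CCNc1nc(-c2ccc(NC(=O)Nc3ccc(Cl)cc3Cl)cc2)nc2c(Cl)c(Cl)sc12` is not yet measured in this assay. It differs from compound 2 by chloro in place of hydrogen on an aromatic carbon, with the dimethylamino chain of compound 2 kept. The expectation for compound 3 is a small weakening, about at the edge of the scatter, given the higher number of compound 1 with the same 2,4-dichlorophenyl group at 1320 nM; the step of a 1.6-fold higher number from compound 2 to compound 3 (0.21 log units; within the scatter) is the estimate. Compound 3 is estimated at 750 nM, within 280 nM to 2000 nM.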

Compound 3, half-maximal inhibitory concentration: 1280 nM
Compound 3: middle estimate off by 1.7-fold (0.23 log units), on the low side, within the range that was stated.
By their numbers in this assay, from the lowest: compound 2; then compounds 3 and 1 (each within the scatter of the next).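

In this assay, chloro in place of hydrogen on the aromatic carbon ortho to a large group gives a 2.8-fold higher number from compound 2 to compound 3 (0.44 log units; beyond the scatter) with the dimethylamino chain held constant, a modest weakening beyond the scatter. With the 2,4-dichlorophenyl group kept, the chain change gives a 1.0-fold lower number from compound 1 to compound 3 (0.01 log units; within the scatter), so this pair shows no chain effect beyond the scatter. Thus, among the single-place steps shown, only the added chloro shifts the number beyond the scatter, and no available measurement accounts for either step.

On these data alone, it remains open whether fluoro, methyl or methoxy at the same place would give a comparable step. The chain comparison also rests on the 2,4-dichlorophenyl pair alone, leaving open whether the longer chain would behave the same way with a 4-chlorophenyl group.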